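A few compounds are considered here, and "the series" means these few. Any claim that something is new, unique, unknown or untested is made for them only; others in the source may bear on it.

Measured compounds:
- compound 1 `COc1ccc(-c2cc3nccc(-c4cc(OC)c(OC)c(OC)c4)n3n2)cc1N`: 27 nM
- compound 2 `COc1cc(-c2ccnc3cc(-c4cn(C)c5ccccc45)nn23)cc(OC)c1OC`: 95 nM

In a functional assay on MCF7 cells (Homo sapiens) for inhibition, read by CCK-8 assay, with a stated time of 48 h (a higher number here means a weaker inhibitor, a lower number a stronger inhibitor), compound 1 gives 27 nM, the lowest of the two numbers measured; its nearest neighbour is compound 2, and the step of a 3.5-fold higher number from compound 1 to compound 2 (0.55 log units; beyond the scatter) is a modest one that lies beyond the scatter. Compound 3 `COc1cc(-c2ccnc3cc(-c4ccc(C)c(C)c4)nn23)cc(OC)c1OC` is unmeasured. It differs from compound 1 in one place: 3,4-dimethylphenyl in place of 3-amino-4-methoxyphenyl on an aromatic carbon. The change sits on an aromatic carbon of a five-membered aromatic ring with two nitrogen, part of a fused or bridged system of two rings.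

Going by the values given here, only one measured step bears on this: the step from compound 1 to compound 2, which also replaces the 3-amino-4-methoxyphenyl group and gave a 3.5-fold higher number from compound 1 to compound 2 (0.55 log units; beyond the scatter). The 3,4-dimethylphenyl group is a different replacement, so that step is a guide rather than a template, but it points the same way, toward a higher number. Compound 3 is therefore expected to show a step of about a 2.8-fold higher number from compound 1 to compound 3 (0.44 log units; beyond the scatter) in this assay, a modest rise that may or may not clear the scatter. The estimate for compound 3 is 75 nM, with a range from 25 nM to 250 nM.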

Compound 3, half-maximal inhibitory concentration: 26 nM
The estimate for compound 3 lay 2.9-fold (0.46 log units) above the measured number; measured number inside the range.
By their numbers in this assay, from the lowest: compounds 3 and 1 (each within the scatter of the next); then compound 2.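

In this assay, 3,4-dimethylphenyl in place of 3-amino-4-methoxyphenyl on this aromatic carbon gave a 1.0-fold lower number from compound 1 to compound 3 (0.02 log units; within the scatter), so the two groups cannot be told apart here, although the entering group has 0 hydrogen-bond donors and 0 hydrogen-bond acceptors where the leaving group has 1 and 2. Measured against the 1-methyl-1H-indol-3-yl group, 3,4-dimethylphenyl gave a 3.7-fold lower number from compound 2 to compound 3 (0.56 log units; beyond the scatter), which shows that the higher number seen with the indolyl group is not shared by every replacement of 3-amino-4-methoxyphenyl at this carbon, and that the amino and methoxy groups are not required for a number at this level in this pair. No experimental information is at hand to explain these differences or this match.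

Still open, on these data alone, is whether this carbon would keep such a number with a phenyl ring bearing a carboxylic acid, a single methyl group or a saturated cyclohexyl ring. All three numbers come from this assay, so the compounds shown leave open whether compound 1 and compound 3 also stay level in any other test.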